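Ring swaps on the amide carbonyl of the shared core

The compounds below may be only part of what the source reports. "The series", "measured", "known", "first", "only" and "open" are said of these compounds alone.

In an assay on isolated protein for inhibition of cathepsin S (Homo sapiens), read by fluorescence, with a stated time of 20 min (on this read-out higher numbers stand for weaker inhibition and lower numbers for stronger inhibition), compound 1 `N#CC1(NC(=O)[C@@H]2C[C@@H](S(=O)(=O)c3ccccc3)C[C@H]2C(=O)N2CCOCC2)CC1` gives 0.7 nM, the second highest of three numbers. Compound 2 `C[C@@H]1CN(C(=O)[C@@H]2C[C@H](S(=O)(=O)c3ccccc3)C[C@H]2C(=O)NC2(C#N)CC2)C[C@H](C)O1` gives 0.4 nM and compound 3 `N#CC1(NC(=O)[C@@H]2C[C@@H](S(=O)(=O)c3ccccc3)C[C@H]2C(=O)N2CCC(O)CC2)CC1` gives 1 nM. The step of a 1.8-fold lower number from compound 1 to compound 2 (0.24 log units; within the scatter) and the step of a 1.4-fold higher number from compound 1 to compound 3 (0.15 log units; within the scatter) both stay within the scatter, while a 2.5-fold higher number from compound 2 to compound 3 (0.40 log units; beyond the scatter) is a modest step beyond it. Compound 4 `N#CC1(NC(=O)[C@@H]2C[C@@H](S(=O)(=O)c3ccccc3)C[C@H]2C(=O)N2CCS(=O)(=O)CC2)CC1` differs from compound 1 by 1,1-dioxothiomorpholin-4-yl in place of morpholin-4-yl on a carbonyl carbon. The two measured changes at the same carbonyl carbon bear on this one; both left the number within the scatter of compound 1, and the change in compound 4 likewise keeps a six-membered non-aromatic ring with 2 hetero atoms at that place. No step beyond the scatter is therefore expected in this assay. Compound 4 is estimated at 1 nM, within 0.4 nM to 2.5 nM. The expected step is a 1.4-fold higher number from compound 1 to compound 4 (0.15 log units; within the scatter).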

Compound 4, half-maximal inhibitory concentration: 4 nM
For compound 4 the middle estimate is 4.0-fold (0.60 log units) below the measured one; the measured number lies above the stated range.
By their numbers in this assay, from the lowest: compounds 2, 1 and 3 (each within the scatter of the next, the first and the last beyond it); then compound 4.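

For the compounds shown here, at the carbonyl carbon, the ring is less freely exchangeable than the earlier compounds suggested: 1,1-dioxothiomorpholin-4-yl moves the number beyond the scatter against all three of them (a 5.7-fold higher number from compound 1 to compound 4 (0.76 log units; beyond the scatter)) (a 4.0-fold higher number from compound 3 to compound 4 (0.60 log units; beyond the scatter)) (a 10-fold higher number from compound 2 to compound 4 (1.00 log units; beyond the scatter)). A six-membered non-aromatic ring with 2 hetero atoms at this place therefore does not by itself hold the number within the scatter of compound 1. Nothing measured here accounts for this step.

Open, going by these compounds, is how thiomorpholin-4-yl, with the ring sulfur but without its two oxygens, would read at this carbonyl carbon. Piperazin-1-yl and an open-chain dimethylamino group are equally open there.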